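Vero cytotoxicity notes: chain extension on the aniline nitrogen

The compounds below may be only part of what the source reports. "The series", "measured", "known", "first", "only" and "open" are said of these compounds alone.

Measured compounds:
- compound 1, `CCCCCCCCCCCCNc1ccc(C(=O)C2CC2c2ccc(Cl)cc2)cc1`: 386 ug/mL
- compound 2, `CCCCCCCCCCCCCCCCNc1ccc(C(=O)C2CC2c2ccc(Cl)cc2)cc1`: 410 ug/mL
- compound 3, `CCCCCCCCNc1ccc(C(=O)C2CC2c2ccc(Cl)cc2)cc1`: 214 ug/mL

All three share one core and differ only in the length of the saturated chain on the aromatic nitrogen. In an ADME assay on Vero cells (Chlorocebus sabaeus) for cytotoxicity, with a stated time of 72 h (a higher number here means that more compound is tolerated, a lower number that less compound is tolerated), compound 3 sits at the low end of the three numbers, but the distance to the others is small: a 1.8-fold lower number from compound 1 to compound 3 (0.26 log units; within the scatter) and a 1.9-fold lower number from compound 2 to compound 3 (0.28 log units; within the scatter) are both within the scatter, and a 1.1-fold higher number from compound 1 to compound 2 (0.03 log units; within the scatter) is likewise within the scatter. Across this set, lengthening the chain has not moved the number beyond what repeated measurement would give.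

Compound 4, `CCCCCCCC/C=C\CCCCCCCCNc1ccc(C(=O)C2CC2c2ccc(Cl)cc2)cc1`, is not yet measured. Relative to compound 3 the change is dec-1-en-1-yl in place of hydrogen on a saturated chain carbon, eight bonds along the chain from a nitrogen on an aromatic ring. The two steps that bear on this are the chain extensions already seen, a 1.8-fold lower number from compound 1 to compound 3 (0.26 log units; within the scatter) read in reverse and a 1.9-fold lower number from compound 2 to compound 3 (0.28 log units; within the scatter) read in reverse, each a small rise that stayed within the scatter. The extension in compound 4 is of similar size, with one double bond in the chain, and nothing in the measured set points to a larger effect. The expected step is therefore a 1.6-fold higher number from compound 3 to compound 4 (0.21 log units; within the scatter), a modest rise that is not expected to exceed the scatter. Compound 4 is estimated at 350 ug/mL in this assay, with a range from 190 ug/mL to 650 ug/mL.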

Compound 4, half-maximal cytotoxic concentration: 393 ug/mL
For compound 4 the middle estimate is 1.1-fold (0.05 log units) below the measured one, within the range that was stated.
By their numbers in this assay, from the lowest: compounds 3, 1, 4 and 2 (each within the scatter of the next).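

At the position eight bonds along the chain from the nitrogen on the aromatic ring, dec-1-en-1-yl in place of hydrogen brings in the only double bond outside aromatic rings in this set, and in this assay the result is a 1.8-fold higher number from compound 3 to compound 4 (0.26 log units; within the scatter) and so stays within the scatter, as the saturated chains did. Comparison with those saturated chains gives a 1.0-fold lower number from compound 2 to compound 4 (0.02 log units; within the scatter) for dec-1-en-1-yl in place of octyl and a 1.0-fold higher number from compound 1 to compound 4 (0.01 log units; within the scatter) for dec-1-en-1-yl in place of butyl, so among these four compounds the unsaturated chain is not separated from the saturated ones by more than the scatter. No other data are at hand that bear on why these numbers lie so close together.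

An octadecyl chain on the aromatic nitrogen would be needed to tell the double bond in compound 4 apart from its chain length. The compounds shown also leave open how a much shorter chain such as butyl, or an amine or a carboxylic acid at the chain end, would read in this assay at this position.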